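A few compounds are considered here, and "the series" means these few. Any claim that something is new, unique, unknown or untested is made for them only; others in the source may bear on it.

Compound 2 `CCOC(=O)c1cnc(N2CCN(Cc3ccccc3C#N)CC2)nc1Oc1c(C)cc(-c2ccc(C#N)cc2)cc1C` is a close relative of compound 1 `CCOC(=O)c1cnc(N2CCN(Cc3ccc(C#N)cc3)CC2)nc1Oc1c(C)cc(-c2ccc(C#N)cc2)cc1C`. In an ADME assay on MT4 cells (Homo sapiens) for cytotoxicity, read by MTT assay, with a stated time of 4 days (a higher number here means that more compound is tolerated, a lower number that less compound is tolerated), compound 1 gives only a limit of the assay, > 125000 nM. In this assay compound 2 likewise gives only a limit, > 125000 nM. The step that the two limits leave unreadable from compound 1 to compound 2 cannot be read, since (the limit of > 125000 nM in this assay, at which 2 of the 2 values shown sit). Compound 3 `CCOC(=O)c1cnc(N2CCN(Cc3ccc(C(F)(F)F)cc3)CC2)nc1Oc1c(C)cc(-c2ccc(C#N)cc2)cc1C` differs from compound 2 by 4-(trifluoromethyl)phenyl in place of 2-cyanophenyl on a saturated chain carbon bound to an amine nitrogen in a ring. Within the data shown here, no measured step offers a readable size, so no change beyond the scatter is expected. The expected step is a step that the limit leaves unreadable from compound 2 to compound 3. Compound 3 is therefore estimated to give 150000 nM in this assay, with a range from 60000 nM to 400000 nM.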

Compound 3, half-maximal cytotoxic concentration: > 125000 nM
Compound 3 ended at the assay's limit (the forecaster's own chance of this, stated with the estimate: 80%); the middle value is on the limit's open side.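

In this assay, among these compounds, no step among compound 1, compound 2 and compound 3 can be read: the limit of > 125000 nM in this assay, at which 3 of the 3 values shown sit. The compounds shown leave open whether these groups differ at all in how much compound is tolerated.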